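A Nitrile-Bearing Amide Group Gives Way to an Ester-Bearing One

The compounds below may be only part of what the source reports. "The series", "measured", "known", "first", "only" and "open" are said of these compounds alone.

In an ADME assay on L02 cells (Homo sapiens) for antiproliferative activity, read by MTT assay, with a stated time of 48 h (a lower number here means a stronger inhibitor, a higher number a weaker inhibitor), compound 1 `CCn1c(C(=O)NCCN)ccc1C(CC)(CC)c1ccc(OCCC(O)(CC)CC)c(C)c1` gives 2940 nM and compound 2 `CCn1c(C(=O)N(CCC#N)CCC#N)ccc1C(CC)(CC)c1ccc(OCCC(O)(CC)CC)c(C)c1` gives 37800 nM as the higher of these two numbers. Compound 3 `CCC(C)C(NC(=O)c1ccc(C(CC)(CC)c2ccc(OCCC(O)(CC)CC)c(C)c2)n1CC)C(=O)OC` shows > 50000 nM as a limit of the assay and not a number. Compound 4 `CCOC(=O)CN(C)C(=O)c1ccc(C(CC)(CC)c2ccc(OCCC(O)(CC)CC)c(C)c2)n1CC` differs from compound 2 by a group of 8 heavy atoms (5 carbon, 1 nitrogen, 2 oxygen; no ring) in place of a group of 9 heavy atoms (6 carbon, 3 nitrogen; no ring), on a carbonyl carbon with ((ethoxycarbonyl)methyl)(methyl)amino as the group that enters. The steps of a 13-fold higher number from compound 1 to compound 2 (1.11 log units; beyond the scatter) and an at least 17-fold higher number from compound 1 to compound 3 (1.23 log units; beyond the scatter) are both large, but both start from compound 1 and its smaller group. The nearest measured change is an at least 1.3-fold higher number from compound 2 to compound 3 (0.12 log units; that floor lies within the scatter) which also alters the group on the carbonyl carbon and has a floor within the scatter. No change beyond the scatter is therefore expected, and the estimated step is a 1.1-fold higher number from compound 2 to compound 4 (0.02 log units; within the scatter) in this assay for this swap. Compound 4 is expected at 40000 nM with an estimated range of 15000 nM to 80000 nM in this measurement.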

Compound 4, half-maximal inhibitory concentration: 1990 nM
Beside the measured number, compound 4's estimate is 20-fold (1.30 log units) above it; measured number outside the range, below it.
By their numbers in this assay, from the lowest: compounds 4 and 1 (each within the scatter of the next); then compound 2. At a limit, above all of these: compound 3.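

Size alone does not set the number for a group on this carbonyl carbon: placing ((ethoxycarbonyl)methyl)(methyl)amino there gives a 19-fold lower number from compound 2 to compound 4 (1.28 log units; beyond the scatter) in this assay. The larger group of compound 4 also matches the smaller (2-aminoethyl)amino, with a 1.5-fold lower number from compound 1 to compound 4 (0.17 log units; within the scatter), so compound 4 goes against the earlier link between a larger group and a higher number. Compound 3 has a limit and not a number, and an at least 25-fold lower number from compound 3 to compound 4 (1.40 log units; beyond the scatter) is read from it: the limit of > 50000 nM in this assay, at which 1 of the 4 values shown sits.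

Which part of the entering group matters remains open. The matching carboxylic acid, or a longer chain before the ester, would help to separate the ester from the rest of the group.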